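Swapping butyl for acetyl in a urea pair

This account rests on a few compounds, and the source may have more. Where it says the series, first, only, none or still open, it means among the compounds named here.

Measured so far:
- compound 1, `CCCCc1ccc(NC(=O)N[C@H](C)c2ccccc2)cc1`: 32%
- compound 2, `CCCCc1ccc(NC(=O)N[C@@H](C)c2ccccc2)cc1`: 72%

Among the compounds with values here, in an ADME assay on the whole organism with Oryza sativa as the target, tested at 1 uM (a higher number here means a weaker effect of the compound at the concentration tested, a lower number a stronger effect), compound 1 gives the lowest of the two numbers; its only neighbour is compound 2, which stands a number 40 percentage points higher from compound 1 to compound 2 (beyond the scatter). That difference is the whole of the measured experience here, and it rests on (the fact that compounds 1 and 2 differ only in the configuration as drawn).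

Compound 3, `CC(=O)c1ccc(NC(=O)N[C@H](C)c2ccccc2)cc1`, is the next one to be tested in this assay. It differs from compound 1 by acetyl in place of butyl on an aromatic carbon. Within the data shown here, the single measured step changed configuration and left every group in place, so it says nothing about replacing a chain on the aromatic ring. Among the measured compounds shown here, with no step of that kind to lean on, the expectation is a change no larger than the ordinary scatter, with compound 1 as the anchor.

Compound 3 is therefore expected to give about 40%, within 15% to 70%, which means a number 8 percentage points higher from compound 1 to compound 3 (within the scatter) as an estimate.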

Compound 3, a percentage reported as activity, at one concentration (the size of the read-out at that concentration, not a potency): 93%
Estimate against measurement, compound 3: 53 percentage points below; the whole stated range lies below it.
By their numbers in this assay, from the lowest: compound 1; then compound 2; then compound 3.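

Placing acetyl in place of butyl on an aromatic carbon para to a large group, with the stereocentre left as drawn in compound 1, gives in this assay a number 61 percentage points higher from compound 1 to compound 3 (beyond the scatter). Until now, only a change of configuration had been seen to move this number, and this step shows that the group at this position can move it beyond the scatter as well, towards a weaker effect at the concentration tested. The one available fact about these compounds concerns configuration alone and does not bear on this change of group.

Butyl and acetyl differ at once in heavy atoms, in a double bond outside the ring and in a hydrogen-bond acceptor, so this single pair cannot show which of these differences counts. A propyl chain, an amine or a carboxylic acid at the same position would help separate them, and acetyl paired with the configuration of compound 2 would show whether the two changes act independently.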